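Hydrazone series, methyl on an aromatic oxygen

The source may hold more compounds than are shown below. What is called first, only, known or untested is meant among the compounds shown, and "the series" means these compounds.

Measured compounds:
compound 1, `COc1cc(/C=N/Nc2nc3ccccc3s2)cc(OC)c1O`, a functional assay on cells (Mus musculus) for cytotoxicity, read by MTT assay, with a stated time of 24 h, tested at 10 uM; on this read-out higher numbers stand for a stronger effect at the one concentration tested and lower numbers for a weaker effect: 55%
compound 2, `Oc1ccc(/C=N/Nc2nc3ccccc3s2)cc1O`, this assay: 57%

Working notes. In this assay compound 1 gives 55% and compound 2 gives 57%. The two numbers fall within the scatter of each other, so compound 2 is not set apart from compound 1 by these data; its number simply sits alongside that of compound 1.

Compound 3, `COc1cc(/C=N/Nc2nc3ccccc3s2)ccc1O`, has not been measured. Relative to compound 2 the change is methyl in place of hydrogen on an oxygen on an aromatic ring. Within the data shown here, no step between two measured compounds is available for this change, so its size here rests only on the two values shown. Since both measured numbers lie close together, the expected step of a number 2 percentage points lower from compound 2 to compound 3 (within the scatter) is none beyond the scatter, in no particular direction.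

For compound 3 the estimated value in this assay is 55%, with an expected range from 40% to 68%.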

Compound 3, a percentage reported as activity, at one concentration (the size of the read-out at that concentration, not a potency): 61%
Compound 3: middle estimate off by 6 percentage points, on the low side; measured number inside the range.
By their numbers in this assay, from the lowest: compounds 1, 2 and 3 (each within the scatter of the next).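

Methyl in place of hydrogen on an oxygen on an aromatic ring, which reads as hydroxy to methoxy, gives a number 4 percentage points higher from compound 2 to compound 3 (within the scatter) in this assay, so at this position the read-out does not set the methoxy group apart from the hydroxy group. Hydrogen in place of methoxy on an aromatic carbon gives a number 6 percentage points higher from compound 1 to compound 3 (within the scatter), so this second position shows no separation either, and both single changes are tolerated within this small set. No available data bear on the origin of either step.

The compounds shown leave open whether a longer chain on this oxygen, or an amine or a carboxylic acid in place of the hydroxy group, would give a step beyond the scatter. As far as these compounds go, each number also gives the size of the effect at one tested concentration only, and how the compounds compare at other concentrations stays open.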